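A few compounds are considered here, and "the series" means these few. Any claim that something is new, unique, unknown or untested is made for them only; others in the source may bear on it.

The compounds here share one core and differ in the saturated chain on the carbon bound to two aromatic carbons. In a functional assay on HL-60 cells (Homo sapiens) for cytotoxicity, read by WST assay, with a stated time of 48 h (on this read-out lower numbers stand for stronger inhibition and higher numbers for weaker inhibition), compound 2 (`COc1cc(C(c2ccc(O)c(OC)c2)[C@@H](C)C(C)C)ccc1O`) gives 20000 nM. Compound 1 (`COc1cc(C(c2ccc(O)c(OC)c2)[C@@H](C)[C@@H](C)CO)ccc1O`) gives > 100000 nM, which is a limit and not a number. Compound 3 (`COc1cc(C(c2ccc(O)c(OC)c2)[C@@H](CO)C(C)C)ccc1O`) gives > 100000 nM, which is also a limit. Compound 3 therefore stands at the limit of > 100000 nM in this assay, at which 2 of the 3 values shown sit.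

Compound 4 (`COc1cc(C(c2ccc(O)c(OC)c2)[C@H](CF)C(C)C)ccc1O`) changes one group of compound 3: 1-(fluoromethyl)-2-methylpropyl in place of 1-(hydroxymethyl)-2-methylpropyl, (1-(fluoromethyl)-2-methylpropyl in place of 1-(hydroxymethyl)-2-methylpropyl on a saturated chain carbon bound to two aromatic carbons). Within the data shown here, two measured steps bear on this change, both beyond the scatter. Removing a hydroxy gives an at least 5.0-fold lower number from compound 1 to compound 2 (0.69 log units; beyond the scatter), and adding one gives an at least 5.0-fold higher number from compound 2 to compound 3 (0.69 log units; beyond the scatter). Neither step swaps hydroxy for fluorine, so they are only a guide.

Compound 4 lacks the hydroxy, as compound 2 does at 20000 nM, so a move towards that value is expected in this assay. The expected change is an at least 3.3-fold lower number from compound 3 to compound 4 (0.52 log units; beyond the scatter). For compound 4 the estimated value is 30000 nM, with an expected range from 10000 nM to 100000 nM.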

Compound 4, half-maximal inhibitory concentration: 19000 nM
Compound 4: middle estimate off by 1.6-fold (0.20 log units), on the high side, and the stated range covers the measured number.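

In this assay, replacing 1-(hydroxymethyl)-2-methylpropyl with 1-(fluoromethyl)-2-methylpropyl on the saturated chain carbon bound to two aromatic carbons gives an at least 5.2-fold lower number from compound 3 to compound 4 (0.72 log units; beyond the scatter), the first direct test of swapping this hydroxy for fluorine. The fluorinated chain also gives an at least 5.2-fold lower number from compound 1 to compound 4 (0.72 log units; beyond the scatter), while the comparison with the 1,2-dimethylpropyl chain gives a 1.1-fold lower number from compound 2 to compound 4 (0.02 log units; within the scatter), so the fluorinated chain and the all-carbon chain read alike here. Compound 1 and compound 3, the two compounds with a hydroxy, each give only a limit: the limit of > 100000 nM in this assay, at which 2 of the 4 values shown sit.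

Whether fluorine contributes anything beyond replacing the hydroxy remains open, since the compounds shown cannot separate the two. Also open, as far as these compounds go, is how an amine, a carboxylic acid or a longer chain would read at this position.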